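From compound 2 to compound 4: adding an ethyl group

The compounds below may be only part of what the source reports. "The series", "measured", "known", "first", "only" and "open" are said of these compounds alone.

Compound 1 `S=C(N/N=C/c1cccs1)Nc1ccc(Cl)cc1` gives 2800 nM in a functional assay on NCI/ADR-RES cells (Homo sapiens) for inhibition, read by sulforhodamine B assay, with a stated time of 48 h; on this read-out higher numbers stand for weaker inhibition of growth and lower numbers for stronger inhibition of growth. Compound 2 `S=C(N/N=C/c1cccs1)Nc1ccccc1` reads > 100000 nM in this assay, which is a limit and not a number. Compound 3 `S=C(N/N=C/c1cccs1)Nc1cccnc1` reads > 100000 nM, also a limit. Compound 2 thus stands at the limit of > 100000 nM in this assay, at which 2 of the 3 values shown sit, so the starting point for this comparison carries no exact value.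

Compound 4 `CCc1ccc(NC(=S)N/N=C/c2cccs2)cc1` differs from compound 2 by ethyl in place of hydrogen on an aromatic carbon. The ethyl sits on an aromatic carbon of a six-membered aromatic ring of carbon only, para to a large group.

Among the compounds with values here, only one measured step bears on this change: an at least 35-fold higher number from compound 1 to compound 2 (1.55 log units; beyond the scatter), large and beyond the scatter, with hydrogen in place of chloro. Within the data shown here, no measurement yet shows whether ethyl behaves as chloro does. Since compound 1 gives 2800 nM, a large step towards stronger inhibition is expected in this assay. Compound 4 may also stay at the limit. The expected change is an at least 16-fold lower number from compound 2 to compound 4 (1.22 log units; beyond the scatter). Compound 4 is estimated at 6000 nM, with an expected range of 1000 nM to 60000 nM.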

Compound 4, concentration for 50% growth inhibition: > 100000 nM
Compound 4: no number, only a limit (the forecaster's own chance of this, stated with the estimate: 30%); middle value at least 16-fold (1.22 log units) away from the limit.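

Ethyl at this place does not stand in for chloro: in this assay, the swap gives an at least 35-fold higher number from compound 1 to compound 4 (1.55 log units; beyond the scatter). A group on this aromatic carbon is therefore not enough in itself to bring a compound off the limit, and among the compounds shown, only the chloro compound gives a number. The step from compound 2 to compound 4 cannot be read, as both ends are limits, and the series now gathers there: the limit of > 100000 nM in this assay, at which 3 of the 4 values shown sit.

Going by these compounds, it remains open whether a reading on this carbon is tied to chloro alone or would also appear with bromo, fluoro, methoxy or trifluoromethyl in its place. Nor do the limits tell how far hydrogen and ethyl each lie from a measurable value, so these two groups cannot be ranked.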